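The source may hold more compounds than are shown below. What is called first, only, known or untested is meant among the compounds shown, and "the series" means these compounds.

Of the compounds shown here, two have so far been measured in an assay on isolated protein for inhibition of phosphodiesterase 4A (Sus scrofa); a lower number here means a stronger inhibitor, a higher number a weaker inhibitor. Compound 1 `CCCCOc1cc(C(=O)Nc2c(F)cccc2F)ccc1OC` gives 300 nM. Compound 2 `COc1ccc(C(=O)Nc2c(Cl)cncc2Cl)cc1OC` gives 100 nM, the lower of the two numbers, with compound 1 sitting higher by a gap that lies beyond the usual scatter. The next compound, compound 3 `CCCCOc1cc(C(=O)Nc2c(Cl)cncc2Cl)ccc1OC`, differs from compound 2 by propyl in place of hydrogen on a saturated chain carbon bound to an oxygen on an aromatic ring. Compound 1 and compound 2 differ from each other in more than one place, so their two values alone do not show what this single change does. The step from compound 2 to compound 3 is expected to be modest, a 2.0-fold lower number from compound 2 to compound 3 (0.30 log units; within the scatter), toward a somewhat lower number. For compound 3 the estimate is 50 nM, within a range of 15 nM to 200 nM.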

Compound 3, half-maximal inhibitory concentration: 8 nM
The estimate for compound 3 lay 6.3-fold (0.80 log units) above the measured number, outside the stated range (below it).
By their numbers in this assay, from the lowest: compound 3; then compound 2; then compound 1.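

In this assay, going from methoxy to butoxy gives a 13-fold lower number from compound 2 to compound 3 (1.10 log units; beyond the scatter) and so counts as a large step, which shows that this chain position matters when the 3,5-dichloropyridin-4-yl group is present. With butoxy kept, 3,5-dichloropyridin-4-yl in place of 2,6-difluorophenyl on an amide-type nitrogen gives a 38-fold lower number from compound 1 to compound 3 (1.57 log units; beyond the scatter) and is also large, so the number responds strongly to changes in both places. From the compounds shown here alone, whether a longer chain such as hexyloxy, or a chain ending in an amine, would lower the number further remains open. No measurement shown here explains why either step is so large.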